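A few compounds are considered here, and "the series" means these few. Any claim that something is new, unique, unknown or untested is made for them only; others in the source may bear on it.

Measured in a functional assay on Jurkat cells (Homo sapiens) for antiproliferative activity, read by MTT assay, with a stated time of 72 h; a higher number here means a weaker inhibitor, a lower number a stronger inhibitor:
- compound 1 `COc1cc(C(=O)c2sc3ccccc3c2-c2ccc(Cl)cc2)cc(OC)c1OC`: 3700 nM
- compound 2 `COc1ccc(OC)c(-c2c(C(=O)c3cc(OC)c(OC)c(OC)c3)sc3ccccc23)c1`: > 10000 nM (a limit of the assay, not a number)
- compound 3 `CCOc1ccc(Nc2c(C(=O)c3cc(OC)c(OC)c(OC)c3)sc3ccccc23)cc1`: 300 nM

Compound 3 has the lower of the two numeric values, at 300 nM. Compound 4 `CCOc1ccc(Nc2c(C(=O)c3cc(OC)c(OC)c(OC)c3)sc3cc(C)ccc23)cc1` differs from it by methyl in place of hydrogen on an aromatic carbon of the six-membered aromatic ring of carbon only. The measured steps of a 12-fold lower number from compound 1 to compound 3 (1.09 log units; beyond the scatter) and an at least 33-fold lower number from compound 2 to compound 3 (1.52 log units; beyond the scatter) are large, but both replace another group, so neither speaks directly to this change. Compound 4 keeps the (4-ethoxyphenyl)amino group, so a value near that of compound 3 is expected in this assay. The expected step is a 1.4-fold lower number from compound 3 to compound 4 (0.13 log units; within the scatter), with no step beyond the scatter expected in either direction. The estimate for compound 4 is 220 nM, within an estimated range of 50 nM to 1000 nM.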

Compound 4, half-maximal inhibitory concentration: 5000 nM
For compound 4 the middle estimate is 23-fold (1.36 log units) below the measured one, outside the stated range (above it).
By their numbers in this assay, from the lowest: compound 3; then compounds 1 and 4 (each within the scatter of the next). At a limit, above all of these: compound 2.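

Methyl in place of hydrogen on the six-membered aromatic ring of carbon only gives a 17-fold higher number from compound 3 to compound 4 (1.22 log units; beyond the scatter) in this assay. Among these compounds, the earlier steps changed only the group carrying the 4-chlorophenyl, 2,5-dimethoxyphenyl or (4-ethoxyphenyl)amino substituent, so this is the first reading on this ring: keeping the (4-ethoxyphenyl)amino group does not by itself hold the number low, and one added methyl at this position is enough to raise it. Nothing shown gives a reason for this rise. Still open, going by these compounds, is whether fluorine, methoxy or hydroxyl at this carbon gives the same rise, and whether methyl on another carbon of this ring does.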